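The compounds below may be only part of what the source reports. "The series", "measured", "known", "first", "only" and "open" are said of these compounds alone.

Four compounds share one core and differ in two places. Compound 1 `Cn1cc(-c2cnc3ccc(NC(=O)c4ccc(F)cc4)nc3c2)cn1` carries a fluoro group on its outer ring, and compound 2 `COc1ccc(C(=O)Nc2ccc3ncc(-c4cnn(C)c4)cc3n2)cc1` carries a methoxy group at the same spot. Compound 3 `Cn1cc(-c2cnc3ccc(NCc4ccc(F)cc4)nc3c2)cn1` keeps the fluoro group but joins the outer ring to the core through a different linkage, and compound 4 `COc1ccc(CNc2ccc3ncc(-c4cnn(C)c4)cc3n2)cc1` combines that linkage with the methoxy group. The difference between the core of compound 1 and the core of compound 3 is not broken down here.

All were examined in a functional assay on HeLa cells (Homo sapiens) for antiproliferative activity, read by MTT assay, with a stated time of 48 h; a lower number here means a stronger inhibitor, a higher number a weaker inhibitor. For compound 1 the result is only a limit of the assay, > 50000 nM. Compound 2 gives 4900 nM. Compound 3 gives 46600 nM, the higher of the two actual numbers, with compound 2 sitting nearest to it.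

The change from compound 1 to compound 2 is methoxy in place of fluoro on an aromatic carbon, and it produced an at least 10-fold lower number from compound 1 to compound 2 (1.00 log units; beyond the scatter); since compound 1 sits at the limit of > 50000 nM in this assay, at which 1 of the 3 values shown sits, only the lower bound of that step is known. Compound 4 differs from compound 3 by methoxy in place of fluoro on an aromatic carbon, the same change at the same place on a different linkage.

For compound 4 a step of a 9.3-fold lower number from compound 3 to compound 4 (0.97 log units; beyond the scatter) is expected, resting on an at least 10-fold lower number from compound 1 to compound 2 (1.00 log units; beyond the scatter). Compound 4 is therefore estimated at 5000 nM, expected to fall between 1500 nM and 20000 nM in this assay.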

Compound 4, half-maximal inhibitory concentration: > 50000 nM
Compound 4 gave a limit, no number; the forecaster's own chance of this, stated with the estimate: 5%; middle value at least 10-fold (1.00 log units) from the limit.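

Replacing fluoro with methoxy on the outer ring does not behave the same way on the two cores in this assay. On the second core the change gives an at least 1.0-fold higher number from compound 3 to compound 4 (0.03 log units; that floor lies within the scatter), and this differs clearly from its effect on the first: the same change on two cores in this assay, an at least 10-fold lower number (1.00 log units; beyond the scatter) from compound 1 to compound 2 and an at least 1.0-fold higher number (0.03 log units; that floor lies within the scatter) from compound 3 to compound 4, at least 10-fold (1.03 log units) apart, beyond the scatter of two such steps

The lower number seen for compound 2 therefore cannot be assumed to carry over when the linkage to the outer ring changes, and compound 4 shows no such gain over compound 3. This does not show the true size of either step or the reason the two differ, and compound 1 and compound 4 each stand at a limit of the assay, not at an actual number: the limit of > 50000 nM in this assay, at which 2 of the 4 values shown sit.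

The compounds shown leave open whether other groups at this place on the outer ring, such as chloro, an amine or a carboxylic acid, would also respond differently on the two cores. With only fluoro and methoxy compared on two linkages, they also cannot tell whether the low number of compound 2 is an isolated result or part of a wider trend.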